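The compounds below may be only part of what the source reports. "The series", "measured", "known", "first", "only" and "open" are said of these compounds alone.

Compound 1, `N=C(N)NCCC[C@H](NC(=O)CN(c1ncnc2c1ncn2C1CCCCO1)C1CC1)C(=O)OCc1ccccc1`, stands highest of the three numbers in hand: in a functional assay on the whole organism (Tail, strain ICR) with Mus musculus as the target, in the tail flick test, with a stated time of 90 min, at a dose of 25 umol/kg by the oral route (a lower number here means a weaker effect, a higher number a stronger effect of the compound at the dose given), compound 1 gives 61.6%. Compound 2, `N=C(N)NCCC[C@H](NC(=O)CN(c1nc(Cl)nc2[nH]cnc12)C1CC1)C(=O)OCc1ccccc1`, gives 30.4%, and compound 3, `O=C(CN(c1nc(Cl)nc2[nH]cnc12)C1CC1)N[C@@H](CC(=O)OCc1ccccc1)C(=O)OCc1ccccc1`, gives 15.6%. Going by the values given here, the one step between measured compounds that differ in a single place, a number 14.8 percentage points lower from compound 2 to compound 3 (beyond the scatter), swapped the same chain that is at issue here for a larger group and lowered the response.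

Compound 4, `C[C@H](NC(=O)CN(c1ncnc2c1ncn2C1CCCCO1)C1CC1)C(=O)OCc1ccccc1`, is compound 1 with a hydrogen atom in place of a group of 6 heavy atoms (3 carbon, 3 nitrogen; no ring), on a saturated chain carbon, two bonds along the chain from an amide-type nitrogen and a carbonyl carbon. Among the compounds with values here, no measured step removes this group outright, but the step from compound 2 to compound 3, which replaced it, already cost activity, and compound 1 with the group intact is the strongest of the three. Within the data shown here, a drop beyond the scatter is therefore expected for compound 4, with the size uncertain because a number 14.8 percentage points lower from compound 2 to compound 3 (beyond the scatter) is the only comparable change. Compound 4 is estimated to give 25%, within 5% to 48%, a step of a number 36.6 percentage points lower from compound 1 to compound 4 (beyond the scatter) expected from compound 1.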

Compound 4, a percentage reported as activity, at one dose (the size of the read-out at that dose, not a potency): 32.1%
Compound 4: middle estimate off by 7.1 percentage points, on the low side; the range from low to high includes it.
By their numbers in this assay, from the lowest: compound 3; then compounds 2 and 4 (each within the scatter of the next); then compound 1.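

In this assay the group of 6 heavy atoms was taken away outright, with a hydrogen atom in its place, and the outcome is a number 29.5 percentage points lower from compound 1 to compound 4 (beyond the scatter) on the shared core, which shows that losing the group lowers the response, and not only swapping it for a larger group as on the core of compound 2. The response does not vanish with the group, since compound 4 still gives 32.1% at this dose. Nothing measured here accounts for the loss.

Going by these compounds, whether a shorter chain ending in a primary amine, or a carboxylic acid on this saturated chain carbon, would hold the response of compound 1 remains open. So does whether a hydrogen atom in place of the group would lower the response by a similar amount on the core of compound 2.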